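The source may hold more compounds than are shown below. What is called first, only, known or untested is meant among the compounds shown, and "the series" means these compounds.

Measured compounds:
compound 1, `CC(C)(C)C1=NN(c2cccc(Cl)c2)C(c2ccc(O)cc2)C1`, 96.8%
compound 2, `CC(C)(C)C1=NN(c2ccc(F)cc2F)C(c2ccc(O)cc2)C1`, 68%
compound 3, `CC(C)(C)C1=NN(c2ccc(F)c(Cl)c2)C(c2ccc(O)cc2)C1`, 98.8%

In an assay on isolated protein for inhibition of protein kinase C zeta type (Homo sapiens), with a stated time of 4 min, tested at 62.5 uM (on this read-out lower numbers stand for less inhibition and higher numbers for more inhibition at the one concentration tested (going by the name of the read-out)), compound 1 gives 96.8% and compound 2 gives 68%. The two differ in the group on the ring nitrogen: 2,4-difluorophenyl in place of 3-chlorophenyl on an amine nitrogen in a ring. This change reads a number 28.8 percentage points lower from compound 1 to compound 2 (beyond the scatter), and compound 2 stands lowest of the three measured numbers. Compound 3 gives 98.8%; against compound 2 the step is a number 30.8 percentage points higher from compound 2 to compound 3 (beyond the scatter).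

Compound 3 arises from compound 1 by a single change, (fluoro in place of hydrogen on an aromatic carbon), and the step is a number 2 percentage points higher from compound 1 to compound 3 (within the scatter), so within the scatter of this assay no change is seen.

Not yet measured is compound 4, `CC(C)(C)C1=NN(c2ccc(F)c(F)c2F)C(c2ccc(O)cc2)C1`. It arises from compound 2 by fluoro in place of hydrogen on an aromatic carbon. This is the same kind of change as from compound 1 to compound 3, but the surroundings of the place differ: in compound 3 the entering fluoro sits ortho to a chloro group and para to a large group, whereas in compound 4 it sits ortho to two fluoro groups and meta to a large group.

Among the compounds with values here, the expectation for compound 2 to compound 4 is a step of about a number 3 percentage points higher from compound 2 to compound 4 (within the scatter) in this assay, resting on the one earlier instance, a number 2 percentage points higher from compound 1 to compound 3 (within the scatter), which stayed within the scatter. Within the data shown here, compound 4 is therefore estimated at 71% in this assay, with the range 50% to 90% kept wide because only one example of this kind of change is available and its surroundings differ.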

Compound 4, a percentage reported as inhibition, at one concentration (the size of the read-out at that concentration, not a potency): 91.7%
Beside the measured number, compound 4's estimate is 20.7 percentage points below it, and the stated range ends below it.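

In this assay, fluoro in place of hydrogen on an aromatic carbon gives a number 23.7 percentage points higher from compound 2 to compound 4 (beyond the scatter). Set beside the earlier instance, the change does not carry from one core to the other as a fixed step: the same change on two cores in this assay, a number 2 percentage points higher (within the scatter) from compound 1 to compound 3 and a number 23.7 percentage points higher (beyond the scatter) from compound 2 to compound 4, 21.7 percentage points apart, beyond the scatter of two such steps

This shows that the size of the step depends on the surroundings of the place in this series, but two instances do not show which feature of the aryl group on the ring nitrogen sets that size, and with compound 1 at 96.8% and compound 3 at 98.8%, both near the top of the scale at the one concentration tested, this read-out may have little room to show a further rise on that core.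

The compounds shown leave open how a bromo, methoxy or trifluoromethyl group would read on the same aromatic carbon, and whether the step would hold at lower concentrations, where values near the top of the scale might separate. They also leave open how the series responds when the tert-butyl group gives way to a longer chain or the hydroxy group on the other aryl ring gives way to an amine or a carboxylic acid.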